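Capping the Phenol: Hydroxy to Phenoxy on the Benzoyl Ring

The source may report more compounds than this note shows. Statements on the series, on what has been measured and on what is new or still open speak of the compounds shown alone.

Compound 1 `CC(/C=N/Nc1ccc([N+](=O)[O-])cc1)=N\NC(=O)c1ccccc1O` gives 29500 nM in an ADME assay on J774 cells (Mus musculus, strain BALB/c) for cytotoxicity, read by resazurin assay, with a stated time of 72 h (a lower number here means that less compound is tolerated, a higher number that more compound is tolerated), the lowest of the two numbers measured. Compound 2 `CC(/C=N/Nc1ccc([N+](=O)[O-])cc1)=N\NC(=O)c1ccc(O)cc1` gives 51000 nM, and a 1.7-fold higher number from compound 1 to compound 2 (0.24 log units; within the scatter). Compound 3 `CC(/C=N/Nc1ccc([N+](=O)[O-])cc1)=N\NC(=O)c1cccc(C)c1` reaches only a limit in this assay, > 100000 nM. The step of an at least 3.3-fold higher number from compound 1 to compound 3 (0.53 log units; beyond the scatter), a change noted as the limit of > 100000 nM in this assay, at which 1 of the 3 values shown sits. Compound 4 `CC(/C=N/Nc1ccc([N+](=O)[O-])cc1)=N\NC(=O)c1ccccc1Oc1ccccc1` differs from compound 1 by phenyl in place of hydrogen on an oxygen on an aromatic ring. Neither measured step touches this oxygen; both swapped the whole ring, and both moved toward a higher number or no change. Compound 4 is therefore expected to give about 50000 nM, between 20000 nM and 120000 nM. The expected change is a 1.7-fold higher number from compound 1 to compound 4 (0.23 log units; within the scatter), a guarded estimate.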

Compound 4, half-maximal cytotoxic concentration: > 100000 nM
Compound 4 ended at the assay's limit; the forecaster's own chance of this, stated with the estimate: 30%; at least 2.0-fold (0.30 log units) between middle value and limit.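

Earlier steps swapped the whole ring, whereas this one keeps the ring and its oxygen and changes only what sits on that oxygen. In this assay, phenyl in place of hydrogen gives an at least 3.3-fold higher number from compound 1 to compound 4 (0.53 log units; beyond the scatter), so this single change alone moves the number beyond the scatter. Compound 4 stands at a limit, so the step has a floor but no known end: the limit of > 100000 nM in this assay, at which 2 of the 4 values shown sit.

On these data alone, what remains open is whether a methyl group on this oxygen, or an amine in place of the oxygen, would move the number the same way.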